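The compounds below may be only part of what the source reports. "The series", "measured", "known", "first", "only" and "open" are said of these compounds alone.

Measured compounds:
- compound 1 `Cc1ncccc1-c1cnc(NCc2c(F)cc(Cl)c3c2CCO3)n2cnnc12`: 2400 nM
- compound 2 `Cc1cc(F)c(CNc2ncc(-c3cccnc3C)c3nncn23)c2c1OCC2`: "not determined" (no result reported)
- compound 3 `Cc1ncccc1-c1cnc(NCc2c(F)cc(C3CC3)c3c2CCO3)n2cnnc12`: "not determined" (no result reported)

In an assay on isolated protein for binding affinity to Polycomb protein EED (Homo sapiens), read by surface plasmon resonance (a higher number here means weaker binding, a lower number tighter binding), compound 1 gives 2400 nM. In this assay compound 2 gives "not determined" (no result reported) and compound 3 gives "not determined" (no result reported), so compound 3 stands without a number, and one further compound is in the same position. Compound 4 `Cc1ncccc1-c1cnc(NCc2c(F)cc(C#N)c3c2CCO3)n2cnnc12` differs from compound 3 in one place: cyano in place of cyclopropyl on an aromatic carbon. Within the data shown here, no step between two measured compounds has been recorded, so nothing shows how large a change of this kind is in this assay or which way it runs. Among the measured compounds shown here, the only anchor is the value of compound 1, a close relative, and a step of no more than the usual scatter is expected. Compound 4 is therefore expected at about 2000 nM, in a range from 500 nM to 8000 nM.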

Compound 4, dissociation constant: 15000 nM
Estimate against measurement, compound 4: 7.5-fold (0.88 log units) below; the measured number lies above the stated range.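

Among these compounds, this is the first readable step at this position: in this assay, putting cyano in place of chloro on the aromatic carbon gives a 6.3-fold higher number from compound 1 to compound 4 (0.80 log units; beyond the scatter) and so weaker binding, which shows that the group here matters. The step from compound 3 to compound 4 cannot be read, since compound 3 has no number. Nothing measured here gives a reason for the change.

Still open, as far as these compounds go, is whether cyclopropyl, as in compound 3, binds tighter or weaker than chloro. From the compounds shown here alone, how a methoxy group or an amine would fare at this place is also open.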